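The source may report more compounds than this note shows. Statements on the series, on what has been measured and on what is new or still open speak of the compounds shown alone.

Compound 3 `C[Se]c1c(SCC#CCO)cnc2ccccc12` gives 3.5 ug/mL in a functional assay on SW707 cells (Homo sapiens) for cytotoxicity, read by sulforhodamine B assay, with a stated time of 72 h (on this read-out higher numbers stand for weaker inhibition and lower numbers for stronger inhibition), the lowest of the three numbers shown; compound 1 `OCC#CCSc1cnc2ccccc2c1Cl` with 6.2 ug/mL lies within the scatter of it (a 1.8-fold lower number from compound 1 to compound 3 (0.25 log units; within the scatter)), whereas compound 2 `OCC#CCSc1cnc2ccccc2c1SCC#CCBr` with 36.2 ug/mL sits clearly apart (a 10-fold lower number from compound 2 to compound 3 (1.01 log units; beyond the scatter)). Compound 4 `C#CC[Se]c1c(SCC#CCO)cnc2ccccc12` differs from compound 3 by ethynyl in place of hydrogen on a saturated chain carbon bound to a selenium atom. Within the data shown here, no measured step alters the chain on the selenium atom, so none bears on it directly; the nearest analogy is a 5.8-fold higher number from compound 1 to compound 2 (0.77 log units; beyond the scatter), where a group of 6 heavy atoms in place of one chlorine atom on an aromatic carbon gave a higher number. On that basis a modest rise in this assay is expected, though a step within the scatter cannot be excluded. Compound 4 is estimated at 6.5 ug/mL, range 2.5 ug/mL to 17 ug/mL. The expected step is thus a 1.9-fold higher number from compound 3 to compound 4 (0.27 log units; within the scatter).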

Compound 4, concentration for 50% inhibition: 3.8 ug/mL
For compound 4 the middle estimate is 1.7-fold (0.23 log units) above the measured one, within the range that was stated.
By their numbers in this assay, from the lowest: compounds 3, 4 and 1 (each within the scatter of the next); then compound 2.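

In this assay, methyl to propargyl on the selenium atom leaves the number within the scatter (a 1.1-fold higher number from compound 3 to compound 4 (0.04 log units; within the scatter)), so this chain tolerates the added ethynyl. The selenium-bearing group of compound 4 matches the chlorine atom within the scatter (a 1.6-fold lower number from compound 1 to compound 4 (0.21 log units; within the scatter)), while replacing the larger sulfur- and bromine-bearing group gives a step beyond it (a 9.5-fold lower number from compound 2 to compound 4 (0.98 log units; beyond the scatter)). No evidence on the cause is at hand.

Open, from the compounds shown here alone, is whether a longer chain on the selenium atom would stay within the scatter. Also open, going by these compounds, is how an amine or a carboxylic acid at the end of that chain would read.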